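This account rests on a few compounds, and the source may have more. Where it says the series, first, only, none or still open, it means among the compounds named here.

Compound 1 `OC[C@H]1O[C@@H](n2cnc3c(NCc4ccc(Br)cc4)ncnc32)[C@H](O)[C@@H]1O` and compound 2 `Cc1ccc(CNc2ncnc3c2ncn3[C@@H]2O[C@H](CO)[C@@H](O)[C@H]2O)cc1` share one core and differ in one place, methyl in place of bromo on an aromatic carbon. In a functional assay on MCF cells (Homo sapiens) for antiproliferative activity, with a stated time of 72 h (a lower number here means a stronger inhibitor, a higher number a weaker inhibitor), compound 1 reaches only the limit of the assay, > 166000 nM. In this assay compound 2 likewise gives only a limit, > 166000 nM. The step that the two limits leave unreadable from compound 1 to compound 2 therefore has no readable size, because both values sit at the limit of > 166000 nM in this assay, at which 2 of the 2 values shown sit. Compound 2 thus stands at that limit and nowhere more precisely. Compound 3 `COc1cccc(CNc2ncnc3c2ncn3[C@@H]2O[C@H](CO)[C@@H](O)[C@H]2O)c1O` differs from compound 2 by 2-hydroxy-3-methoxyphenyl in place of 4-methylphenyl on a saturated chain carbon bound to a nitrogen on an aromatic ring. Among the compounds with values here, the only measured step, which also changes the group on the saturated chain carbon bound to a nitrogen on an aromatic ring, gives no readable size, so no direction of change is expected beyond the scatter in this assay. Compound 3 is therefore expected to give 200000 nM (range 40000 nM to 1000000 nM), a step that the limit leaves unreadable from compound 2 to compound 3.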

Compound 3, half-maximal inhibitory concentration: 20200 nM
The estimate for compound 3 lay 9.9-fold (1.00 log units) above the measured number; measured number outside the range, below it.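

At the saturated chain carbon bound to a nitrogen on an aromatic ring, the choice of group can move the result in this assay: 2-hydroxy-3-methoxyphenyl in place of 4-methylphenyl gives an at least 8.2-fold lower number from compound 2 to compound 3 (0.91 log units; beyond the scatter), and the same group in place of 4-bromophenyl gives an at least 8.2-fold lower number from compound 1 to compound 3 (0.91 log units; beyond the scatter). Compound 3, at 20200 nM, is the only one of the three with a real number rather than a limit, so both steps give only a minimum size. The step between compound 1 and compound 2 cannot be read, and those two compounds stay at the limit: the limit of > 166000 nM in this assay, at which 2 of the 3 values shown sit.

Hydroxy and methoxy enter together, and whether either alone goes with the lower number stays open. On these data alone, how a phenyl ring carrying an amine or a carboxylic acid instead would read also stays open.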